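The source may hold more compounds than are shown below. What is called first, only, known or untested is meant among the compounds shown, and "the series" means these compounds.

Compound 1 `Oc1ccc(O)c(/C=N/c2ccc(OCc3ccccc3)cc2)c1` gives 1230 nM in an assay on isolated protein for inhibition of Amine oxidase [flavin-containing] B (Homo sapiens), read by fluorescence and Amplex Red, with stated times of 15 min and 20 min; on this read-out lower numbers stand for stronger inhibition and higher numbers for weaker inhibition.
Compound 2 `Cc1ccc(/C=N/c2ccc(OCc3ccccc3)cc2)c(O)c1` gives 24400 nM in this assay.
Compound 3 `COc1ccc(/C=N/c2ccc(OCc3ccccc3)cc2)c(O)c1` gives 23600 nM in this assay.

Compound 2 stands at the highest number of the three. Its gap to compound 3 is only a 1.0-fold lower number from compound 2 to compound 3 (0.01 log units; within the scatter), so the two cannot be told apart. Its gap to compound 1 is large: a 20-fold higher number from compound 1 to compound 2 (1.30 log units; beyond the scatter).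

Compound 4 `Cc1ccc(O)c(/C=N/c2ccc(OCc3ccccc3)cc2)c1` has not been measured. It differs from compound 2 by 2-hydroxy-5-methylphenyl in place of 2-hydroxy-4-methylphenyl on a carbon with a double bond to nitrogen. Among the measured compounds shown here, no measured step tries this exact change. The closest guide is a 1.0-fold lower number from compound 2 to compound 3 (0.01 log units; within the scatter), where replacing the methyl by methoxy left the number unchanged, whereas a 20-fold higher number from compound 1 to compound 2 (1.30 log units; beyond the scatter) involved a different hydroxyl pattern. The expected step is therefore a 1.2-fold lower number from compound 2 to compound 4 (0.09 log units; within the scatter), within the scatter. Compound 4 is expected at 20000 nM, with a range of 7000 nM to 60000 nM.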

Compound 4, half-maximal inhibitory concentration: 24600 nM
Beside the measured number, compound 4's estimate is 1.2-fold (0.09 log units) below it; the measured number falls inside the stated range.
By their numbers in this assay, from the lowest: compound 1; then compounds 3, 2 and 4 (each within the scatter of the next).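

Moving the methyl around the ring, with 2-hydroxy-5-methylphenyl in place of 2-hydroxy-4-methylphenyl, gives no readable change in this assay (a 1.0-fold higher number from compound 2 to compound 4 (0.00 log units; within the scatter)). Compound 4 also shows that one swap alone, methyl in place of hydroxy on an aromatic carbon, is enough for a large gap (a 20-fold higher number from compound 1 to compound 4 (1.30 log units; beyond the scatter)). No measured evidence here explains that gap. Still open, going by these compounds, is whether an amine or a fluorine atom in place of that hydroxy would keep the lower number of compound 1.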